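A few compounds are considered here, and "the series" means these few. Any claim that something is new, unique, unknown or untested is made for them only; others in the source may bear on it.

Working notes on the series, read in a functional assay on HCT-116 cells (Homo sapiens) for inhibition, read by MTT assay, with a stated time of 72 h; a lower number here means a stronger inhibitor, a higher number a weaker inhibitor. Compound 1 `COc1cc(Oc2cccc(Nc3ccccc3)c2)cc(OC)c1CNCc1ccccc1` gives 4070 nM, the lowest of the numbers shown. Compound 3 `COc1cc(Oc2cccc(Nc3ccccc3)c2)cc(OC)c1CNCCNC(C)=O` gives 18200 nM, the nearest number to it. Compound 2 `CNCc1c(OC)cc(Oc2cccc(Nc3ccccc3)c2)cc1OC` reads > 20000 nM, which is a limit of the assay and not a number.

Compound 4 `COc1cc(Oc2cccc(Nc3ccccc3)c2)cc(OC)c1CNCc1ccc(Cl)cc1` differs from compound 1 only on the terminal phenyl, with benzylamino becoming (4-chlorobenzyl)amino: chloro in place of hydrogen on an aromatic carbon. The chloro sits on an aromatic carbon, para to a large group.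

Going by the values given here, two measured steps bear on this, and both remove that phenyl entirely: an at least 4.9-fold higher number from compound 1 to compound 2 (0.69 log units; beyond the scatter) and a 4.5-fold higher number from compound 1 to compound 3 (0.65 log units; beyond the scatter). Both are modest at most in the sense that the first is a bound and the second a measured move, and both point to higher numbers without the phenyl. The step of an at least 1.0-fold lower number from compound 2 to compound 3 (0.04 log units; that floor lies within the scatter) adds little, as its floor lies within the scatter. Among the compounds with values here, no measured compound carries a substituent on the phenyl, so the effect of adding one is untested here.

Compound 4 keeps the phenyl, so no step beyond the scatter is expected, with a slight lean to a lower number. The expected change is a 1.4-fold lower number from compound 1 to compound 4 (0.13 log units; within the scatter). Compound 4 is estimated at 3000 nM, with an expected range of 1200 nM to 8000 nM.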

Compound 4, half-maximal inhibitory concentration: 3310 nM
Estimate against measurement, compound 4: 1.1-fold (0.04 log units) below; low and high end bracket the measured number.
By their numbers in this assay, from the lowest: compounds 4 and 1 (each within the scatter of the next); then compound 3. At a limit, above all of these: compound 2.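

In this assay, the aromatic carbon of the terminal phenyl, para to a large group, now has its first reading: chloro in place of hydrogen gives a 1.2-fold lower number from compound 1 to compound 4 (0.09 log units; within the scatter), so at this position the change leaves the result within the scatter of compound 1. The separation from the compounds lacking the ring survives the substitution, as shown by a 5.5-fold lower number from compound 3 to compound 4 (0.74 log units; beyond the scatter), so among the compounds shown, the readings beyond the scatter follow the change from acetamidomethyl or hydrogen to a phenyl-bearing group, and not the chloro. The step of an at least 6.0-fold lower number from compound 2 to compound 4 (0.78 log units; beyond the scatter) is only a floor, as compound 2 stands at a limit of the assay and not at a number: the limit of > 20000 nM in this assay, at which 1 of the 4 values shown sits.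

On these data alone, one chloro at one position says little about other substituents on the ring, so it remains open whether a methoxy group or a carboxylic acid at this place, or a chloro elsewhere on the phenyl, would give a step beyond the scatter. Also open, as far as these compounds go, is how a longer chain carrying the phenyl, or a tertiary amine in place of the secondary amine, would read in this assay.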